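Changing the Phenyl Group on the Ring Amine Nitrogen

The compounds below may be only part of what the source reports. "The series", "measured", "known", "first", "only" and "open" are said of these compounds alone.

Three compounds sharing one core have been tested in a functional assay on CHO cells with adenosine receptor A1 (Homo sapiens) as the target, read by cAMP accumulation and immunoassay, with a stated time of 6 min, tested at 1 uM; a higher number here means a weaker effect of the compound at the concentration tested, a lower number a stronger effect:

Compound 1 `Nc1scc(CN2CCN(c3ccc(F)cc3Cl)CC2)c1C(=O)c1ccc(Cl)cc1` gives -39%.
Compound 2 `Nc1scc(CN2CCN(c3ccc(OC(F)(F)F)cc3)CC2)c1C(=O)c1ccc(Cl)cc1` gives -51%.
Compound 3 `Nc1scc(CN2CCN(c3c(F)cccc3F)CC2)c1C(=O)c1ccc(Cl)cc1` gives -65%.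

Compound 2 stands second highest of these three numbers. It is separated from compound 1 by the step of a number 12 percentage points lower from compound 1 to compound 2 (beyond the scatter) and from compound 3 by the step of a number 14 percentage points lower from compound 2 to compound 3 (beyond the scatter), both beyond the scatter but modest.

Compound 4 `Nc1scc(CN2CCN(c3ccc(Cl)c(Cl)c3)CC2)c1C(=O)c1ccc(Cl)cc1` is not yet measured. Its change from compound 2 is 3,4-dichlorophenyl in place of 4-(trifluoromethoxy)phenyl on an amine nitrogen in a ring. Among the measured compounds shown here, no measured step involves 3,4-dichlorophenyl, so none bears directly on it. The two steps from compound 2 show that exchanging the phenyl group moved the read-out only modestly, so compound 4 is expected to change by a number 1 percentage points lower from compound 2 to compound 4 (within the scatter), within the scatter. Compound 4 is therefore estimated at -52%, in a range from -72% to -30%.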

Compound 4, a percentage reported as activity, at one concentration (the size of the read-out at that concentration, not a potency): -60%
Compound 4: middle estimate off by 8 percentage points, on the high side, and the stated range covers the measured number.
By their numbers in this assay, from the lowest: compounds 3, 4 and 2 (each within the scatter of the next, the first and the last beyond it); then compound 1.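

In this assay a phenyl group with chlorine on two ring carbons also fits on this ring amine nitrogen: the measured steps are a number 9 percentage points lower from compound 2 to compound 4 (within the scatter) and a number 5 percentage points higher from compound 3 to compound 4 (within the scatter) so compound 4 cannot be told apart from either. The step that does stand out is a number 21 percentage points lower from compound 1 to compound 4 (beyond the scatter). Compound 1 also stands apart from compound 2 and compound 3. No measurement shown explains these steps. Open, as far as these compounds go, is how a phenyl ring carrying an amine or a carboxylic acid would behave at this nitrogen, or a longer alkyl chain in place of the phenyl ring.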